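Ethyl ester in the homologous sulfamide series

This account rests on a few compounds, and the source may have more. Where it says the series, first, only, none or still open, it means among the compounds named here.

Measured compounds:
compound 1, `COC(=O)c1ccc(-c2cc(N3CCC(CNS(N)(=O)=O)CC3)ncn2)cc1`: 22900 nM
compound 2, `CCOC(=O)c1ccc(-c2cc(N3CCC(CNS(N)(=O)=O)CC3)ncn2)cc1`: 5700 nM
compound 3, `COC(=O)c1ccc(-c2cc(N3CCC(CCNS(N)(=O)=O)CC3)ncn2)cc1`: 19600 nM

Of the compounds shown here, three have been measured in a functional assay on HT-29 cells (Homo sapiens) for antiproliferative activity, read by sulforhodamine B assay, with a stated time of 48 h; a higher number here means a weaker inhibitor of growth, a lower number a stronger inhibitor of growth. Compound 1 and compound 2 share a core and differ by methyl in place of hydrogen on a saturated chain carbon bound to an oxygen next to a carbonyl group; this change gave a 4.0-fold lower number from compound 1 to compound 2 (0.60 log units; beyond the scatter). Compound 3 differs from compound 1 in the side chain on the saturated ring, by (sulfamoylamino)methyl in place of sulfamoylamino on a saturated chain carbon bound to a saturated ring carbon, and this gave a 1.2-fold lower number from compound 1 to compound 3 (0.07 log units; within the scatter), so compound 1 and compound 3 cannot be told apart on this measurement.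

Compound 4, `CCOC(=O)c1ccc(-c2cc(N3CCC(CCNS(N)(=O)=O)CC3)ncn2)cc1`, is not yet measured. It stands to compound 3 as compound 2 stands to compound 1: the difference is methyl in place of hydrogen on a saturated chain carbon bound to an oxygen next to a carbonyl group, the same change at the same place, seen here a second time on the core of compound 3, a core that differs from that of compound 1 only by the longer side chain already described.

Within the data shown here, because the one earlier instance gave a 4.0-fold lower number from compound 1 to compound 2 (0.60 log units; beyond the scatter), and because the two cores are indistinguishable in this assay, as a 1.2-fold lower number from compound 1 to compound 3 (0.07 log units; within the scatter) shows, compound 4 is expected to follow compound 3 by about a 3.4-fold lower number from compound 3 to compound 4 (0.53 log units; beyond the scatter) in this assay. The expectation rests on a single measured pair and is therefore held loosely. For compound 4 the estimate in this assay is 5800 nM, with a plausible range from 2500 nM to 14000 nM.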

Compound 4, concentration for 50% growth inhibition: 6800 nM
Beside the measured number, compound 4's estimate is 1.2-fold (0.07 log units) below it, and the stated range covers the measured number.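

In this assay, the change from methoxycarbonyl to ethoxycarbonyl on the core with the longer side chain gave a 2.9-fold lower number from compound 3 to compound 4 (0.46 log units; beyond the scatter), and its two instances agree: the same change on two cores in this assay, a 4.0-fold lower number (0.60 log units; beyond the scatter) from compound 1 to compound 2 and a 2.9-fold lower number (0.46 log units; beyond the scatter) from compound 3 to compound 4, 1.4-fold (0.14 log units) apart, within the scatter of two such steps The longer side chain, read this time on the ethyl esters, gave a 1.2-fold higher number from compound 2 to compound 4 (0.08 log units; within the scatter), so it again makes no measurable difference, and the two readings of that change also agree: the same change on two cores in this assay, a 1.2-fold lower number (0.07 log units; within the scatter) from compound 1 to compound 3 and a 1.2-fold higher number (0.08 log units; within the scatter) from compound 2 to compound 4, 1.4-fold (0.14 log units) apart, within the scatter of two such steps Together these show that, across the four compounds, the ester change carries from one core to the other while the side-chain length leaves the number within the scatter, but the result rests on just two pairs, on two cores that differ only in that side chain, and on a single cell line, so it does not show that the change would carry to a more different core, nor why the ethyl ester gives the lower number.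

The compounds shown leave open whether a propyl or isopropyl ester would extend the step, and how a carboxylic acid or an amide in place of the ester would read. They also leave open whether a still longer chain on the saturated ring would stay within the scatter as well.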